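The source may hold more compounds than are shown below. What is called first, only, known or untested is meant among the compounds shown, and "the series" means these compounds.

In an in vitro ADME assay on microsomes from liver (Homo sapiens) for metabolic stability, tested at 1 uM (a higher number here means that the compound lasts longer, a lower number that the compound disappears faster), compound 1 `CS(=O)(=O)Nc1ccc2c(c1)S(=O)(=O)N=C(C1=C(O)[C@@H]3[C@H]4CC[C@H](C4)[C@@H]3N(Cc3ccccc3)C1=O)N2` gives > 1 h which is a limit of the assay and not a number. From the compounds shown here alone, compound 2 `Cc1ccc(CN2C(=O)C(C3=NS(=O)(=O)c4cc(NS(C)(=O)=O)ccc4N3)=C(O)[C@@H]3[C@H]4CC[C@H](C4)[C@@H]32)cc1F` gives > 1 h which is also a limit, so its exact half-life is unknown. Both compounds therefore sit at the limit of > 1 h in this assay, at which 2 of the 2 values shown sit, and nothing separates them. Compound 3 `CS(=O)(=O)Nc1ccc2c(c1)S(=O)(=O)N=C(C1=C(O)[C@@H]3[C@H]4CC[C@H](C4)[C@@H]3N(Cc3ccc(F)c(Cl)c3)C1=O)N2` differs from compound 2 in one group, on a saturated chain carbon bound to an amide-type nitrogen in a ring: 3-chloro-4-fluorophenyl in place of 3-fluoro-4-methylphenyl on a saturated chain carbon bound to an amide-type nitrogen in a ring and the rest of the structure stays the same. Among the measured compounds shown here, the only measured step at that place is a step that the two limits leave unreadable from compound 1 to compound 2 and it offers no size to carry over. No step beyond the scatter is therefore expected in this assay and no direction can be given. The expected change is a step that the limit leaves unreadable from compound 2 to compound 3 as an estimate only. The half-life of compound 3 is estimated at 1.5 h (expected range 0.8 h to 3 h) and it may well be reported as a limit again.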

Compound 3, half-life: > 1 h
Compound 3: no number, only a limit; the forecaster's own chance of this, stated with the estimate: 75%; the middle value is on the limit's open side.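

Among the compounds shown here, compound 3 also gives only a limit in this assay, so no step from compound 1 or compound 2 to compound 3 can be read: the limit of > 1 h in this assay, at which 3 of the 3 values shown sit. From the compounds shown here alone, the actual half-lives of compound 1, compound 2 and compound 3 stay open, and so does whether exchanging these aromatic groups changes the half-life at all.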